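Adding a Methoxy Group to Compound 3

The compounds below may be only part of what the source reports. "The series", "measured", "known", "first", "only" and "open" are said of these compounds alone.

Measured so far in an ADME assay on NHDF cells (Homo sapiens) for cytotoxicity, read by MTT assay, with a stated time of 72 h; a lower number here means a stronger inhibitor, a higher number a weaker inhibitor:
Compound 1 `COc1ccc(/C=C2\CCC/C(=C\c3cccc(Br)c3)C2=O)cc1OC` gives 12400 nM
Compound 2 `COc1ccccc1/C=C1\CCC/C(=C\c2ccc(OC)c(OC)c2)C1=O` gives 18100 nM
Compound 3 `COc1ccc(/C=C2\CCC/C(=C\c3ccc(OC)c(OC)c3)C2=O)cc1` gives 30900 nM

Compound 3 cannot be told apart from compound 2, given a 1.7-fold higher number from compound 2 to compound 3 (0.23 log units; within the scatter), but it clearly sits apart from compound 1, given a 2.5-fold higher number from compound 1 to compound 3 (0.40 log units; beyond the scatter). Compound 4 `COc1ccc(/C=C2\CCC/C(=C\c3ccc(OC)c(OC)c3)C2=O)c(OC)c1` is still unmeasured. It differs from compound 3 at one place: methoxy in place of hydrogen on an aromatic carbon, which is methoxy in place of hydrogen on an aromatic carbon, ortho to a large group and meta to a methoxy group.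

Among the measured compounds shown here, no measured pair adds a group in this way, so the evidence is indirect. The closest change puts 4-methoxyphenyl in place of 2-methoxyphenyl and gives a 1.7-fold higher number from compound 2 to compound 3 (0.23 log units; within the scatter). The step involving compound 1 removes 3-bromophenyl and says less about this change. A small shift toward a lower number is therefore expected, with nothing beyond the scatter. The estimated change is a 1.3-fold lower number from compound 3 to compound 4 (0.11 log units; within the scatter). Compound 4 is estimated at 24000 nM, with an expected range from 12000 nM to 48000 nM.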

Compound 4, half-maximal inhibitory concentration: > 50000 nM
Compound 4: only a limit was reported; the forecaster's own chance of this, stated with the estimate: 5%; middle value at least 2.0-fold (0.31 log units) away from the limit.
By their numbers in this assay, from the lowest: compounds 1, 2 and 3 (each within the scatter of the next, the first and the last beyond it). At a limit, above all of these: compound 4.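

In this assay, methoxy in place of hydrogen on an aromatic carbon, ortho to a large group and meta to a methoxy group, gives an at least 1.6-fold higher number from compound 3 to compound 4 (0.20 log units; that floor lies within the scatter), so adding this group brings no move toward a lower number, although that floor alone does not separate the pair. Among the compounds shown here, a second comparison shows a wider gap, an at least 2.7-fold higher number from compound 2 to compound 4 (0.44 log units; beyond the scatter), the first step from that compound to go beyond the scatter. The reading for compound 4 is a limit of the assay and not a number: the limit of > 50000 nM in this assay, at which 1 of the 4 values shown sits.

From the compounds shown here alone, how far the true value of compound 4 lies past that limit stays open, so the size of this change has only a floor. Going by these compounds, whether a fluorine, a hydroxyl or an amine on this same aromatic carbon would shift the number in the same direction also stays open.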